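The source may hold more compounds than are shown below. What is called first, only, known or untested is meant among the compounds shown, and "the series" means these compounds.

In a functional assay on A549 cells (Homo sapiens) for antiproliferative activity, read by MTT assay, with a stated time of 48 h (a higher number here means a weaker inhibitor, a lower number a stronger inhibitor), compound 1 `O=C(NO)c1ccc(/C=C/c2ccc(O)cc2)o1` gives 86400 nM, compound 2 `O=C(/C=C/c1ccc(/C=C/C(=O)c2cccc(Cl)c2)o1)NO` gives 18900 nM, and compound 3 `O=C(/C=C/c1ccc(/C=C/C(=O)c2ccccc2)o1)NO` gives 20200 nM. Compound 3 therefore sits level with compound 2, within the scatter, and has a clearly lower number than compound 1. Compound 4 `O=C(/C=C/c1ccc(/C=C/C(=O)c2ccc(Cl)cc2)o1)NO` differs from compound 3 in one place, phenyl to 4-chlorophenyl: chloro in place of hydrogen on an aromatic carbon, para to a large group. The closest measured step is a 1.1-fold higher number from compound 2 to compound 3 (0.03 log units; within the scatter), which swaps a chloro on that ring for hydrogen at a different place and stays within the scatter. No step beyond the scatter is therefore expected in this assay. The estimated step is a 1.1-fold lower number from compound 3 to compound 4 (0.03 log units; within the scatter). For compound 4 the expected value is 19000 nM, with an estimated range from 10000 nM to 36000 nM.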

Compound 4, half-maximal inhibitory concentration: 98100 nM
Compound 4: middle estimate off by 5.2-fold (0.71 log units), on the low side, and the stated range ends below it.
By their numbers in this assay, from the lowest: compounds 2 and 3 (each within the scatter of the next); then compounds 1 and 4 (each within the scatter of the next).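

In this assay chloro on the aromatic carbon para to a large group is not a neutral change: it makes a weaker inhibitor, with a 4.9-fold higher number from compound 3 to compound 4 (0.69 log units; beyond the scatter). The place of the chloro also counts, as 4-chlorophenyl in place of 3-chlorophenyl gives a 5.2-fold higher number from compound 2 to compound 4 (0.72 log units; beyond the scatter), while compound 2, with its 3-chlorophenyl, stays within the scatter of compound 3. Nothing shown here explains this difference. Going by these compounds, whether a methoxy or an amine at this place would behave like chloro stays open.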